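This account rests on a few compounds, and the source may have more. Where it says the series, first, only, none or still open, it means among the compounds named here.

Series notes. Measured so far in a functional assay on CHO cells for antagonist activity at prostaglandin E2 receptor EP3 subtype (Homo sapiens), read by cAMP accumulation; on this read-out lower numbers stand for stronger inhibition and higher numbers for weaker inhibition:

- compound 1, `Cc1nc(C(c2ccc(-c3ccc4cccc(F)c4c3)[nH]c2=O)C(C)C)[nH]c1C`, gives 50 nM
- compound 2, `CC(C)C(Nc1nccs1)c1ccc(-c2ccc3cccc(F)c3c2)[nH]c1=O`, gives 10 nM
- compound 3, `CC(C)C(c1noc(=O)[nH]1)c1ccc(-c2ccc3cccc(F)c3c2)[nH]c1=O`, gives 41 nM

Compound 3 sits with compound 1 at the higher end of these three numbers: the step of a 1.2-fold lower number from compound 1 to compound 3 (0.09 log units; within the scatter) does not separate the two, whereas a 4.1-fold higher number from compound 2 to compound 3 (0.61 log units; beyond the scatter) sets compound 3 apart from compound 2.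

Compound 4, `CC(C)C(/C=C1\CCNC1=O)c1ccc(-c2ccc3cccc(F)c3c2)[nH]c1=O`, differs from compound 3 by a group of 7 heavy atoms (5 carbon, 1 nitrogen, 1 oxygen; one five-membered non-aromatic ring with 1 hetero atom) in place of a group of 6 heavy atoms (2 carbon, 2 nitrogen, 2 oxygen; one five-membered aromatic ring with 3 hetero atoms), on a saturated chain carbon bound to an aromatic carbon and a saturated chain carbon. The measured steps that bear on this position are the exchanges of one five-membered aromatic group for another at the same carbon, a 5.0-fold lower number from compound 1 to compound 2 (0.70 log units; beyond the scatter) and a 1.2-fold lower number from compound 1 to compound 3 (0.09 log units; within the scatter). Going by the values given here, those exchanges moved the number by a modest amount at most, and no measured step covers a non-aromatic ring at this place, so nothing points to a large move in either direction. A step of about a 1.2-fold higher number from compound 3 to compound 4 (0.09 log units; within the scatter) is therefore expected, nothing clearly beyond the scatter. Compound 4 is estimated at 50 nM in this assay, within a range of 15 nM to 160 nM.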

Compound 4, half-maximal inhibitory concentration: 8.7 nM
Compound 4: the middle estimate sits 5.7-fold (0.76 log units) above what was measured, and the stated range ends above it.
By their numbers in this assay, from the lowest: compounds 4 and 2 (each within the scatter of the next); then compounds 3 and 1 (each within the scatter of the next).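

At the saturated chain carbon bound to an aromatic carbon and a saturated chain carbon, an aromatic ring is not needed for a low number in this assay, since the five-membered non-aromatic ring of compound 4 gives a 4.7-fold lower number from compound 3 to compound 4 (0.67 log units; beyond the scatter) and a 5.7-fold lower number from compound 1 to compound 4 (0.76 log units; beyond the scatter) at this place. The step of a 1.1-fold lower number from compound 2 to compound 4 (0.06 log units; within the scatter) does not separate this group from the (1,3-thiazol-2-yl)amino group, so two groups of different ring type are tolerated here to the same extent in these data. No measurement that would explain these steps is at hand.

Which part of the entering group matters stays open: the double bond outside the ring, the carbonyl or the amide hydrogen. A carboxylic acid, an amine or an open-chain amide at this carbon would test whether any ring is required.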